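Cinnamoyl Cap in Place of Dimethylaminobenzoyl on Hydroxamate

This account rests on a few compounds, and the source may have more. Where it says the series, first, only, none or still open, it means among the compounds named here.

Compound 1, `O=C(CCCCC[C@H](NC(=O)c1ccc(Br)cc1)C(=O)Nc1ccc(-c2ccccc2)cc1)NO`, gives 149 nM in a functional assay on MCF7 cells (Homo sapiens) for antiproliferative activity; on this read-out higher numbers stand for weaker inhibition and lower numbers for stronger inhibition.
Compound 2, `CN(C)c1ccc(C(=O)N[C@@H](CCCCCC(=O)NO)C(=O)Nc2cccc3cccnc23)cc1`, gives 35 nM in this assay.

Of the two measured compounds, compound 2 stands at the lower number in this assay, and its gap to compound 1 is beyond the scatter of repeated measurements. Compound 3, `O=C(/C=C/c1ccccc1)N[C@@H](CCCCCC(=O)NO)C(=O)Nc1cccc2cccnc12`, has not been measured. It differs from compound 2 in one place: 2-phenylethenyl in place of 4-(dimethylamino)phenyl on a carbonyl carbon. The two measured compounds differ in several places at once, so no single-change comparison is available to anchor the size of this step. On the numbers shown, the expected step of a 1.6-fold higher number from compound 2 to compound 3 (0.20 log units; within the scatter) in this assay is a modest move toward a higher number, not clearly beyond the scatter. Compound 3 is therefore estimated at 55 nM in this assay, within a range from 15 nM to 200 nM.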

Compound 3, half-maximal inhibitory concentration: 17 nM
The estimate for compound 3 lay 3.2-fold (0.51 log units) above the measured number, and the stated range covers the measured number.
By their numbers in this assay, from the lowest: compound 3; then compound 2; then compound 1.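

At the carbonyl carbon whose other neighbour is the amide-type nitrogen, replacing 4-(dimethylamino)phenyl with 2-phenylethenyl gives a 2.1-fold lower number from compound 2 to compound 3 (0.31 log units; beyond the scatter) in this assay on the otherwise unchanged scaffold. The number at this position therefore does not rise when the nitrogen and the hydrogen-bond acceptor of the leaving group are gone and a double bond outside aromatic rings comes in. No measurement shown here accounts for the step.

The change swaps several features at once, so the shares of the lost dimethylamino group and the gained double bond stay unresolved. From the compounds shown here alone, an unsubstituted phenyl or a saturated 2-phenylethyl group on the same carbonyl carbon would separate them, and how such groups would read out in this assay remains open.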